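Lengthening the alkyl chain on a urea series

A few compounds are considered here, and "the series" means these few. Any claim that something is new, unique, unknown or untested is made for them only; others in the source may bear on it.

Measured compounds:
compound 1, `CCc1ccc(NC(=O)N[C@H](C)c2ccccc2)cc1`, 95%
compound 2, `CCc1ccc(NC(=O)N[C@@H](C)c2ccccc2)cc1`, 99%
compound 3, `CC(C)c1ccccc1NC(=O)N[C@@H](C)c1ccccc1`, 99%

In an ADME assay on the whole organism with Oryza sativa as the target, tested at 0.1 uM (on this read-out higher numbers stand for a weaker effect at the one concentration tested and lower numbers for a stronger effect), compound 1 gives 95%. Compound 2 gives 99% and compound 3 gives 99%, and both of these numbers lie within the usual scatter of the number for compound 1, so the three measured compounds are not separated by this read-out. Within the data shown here, the one step measured between neighbours that differ in a single place is a number 4 percentage points higher from compound 1 to compound 2 (within the scatter), a step that rests on the fact that compounds 1 and 2 differ only in the configuration as drawn and that does not leave the scatter.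

The unmeasured compound 4, `CCCCCCc1ccc(NC(=O)N[C@H](C)c2ccccc2)cc1`, departs from compound 1 by butyl in place of hydrogen on a saturated chain carbon, two bonds along the chain from an aromatic carbon; read one bond further out, the change is ethyl to hexyl. Among the measured compounds shown here, none of the measured steps touches the length of this chain, so no measured step bears directly on it. For the measured compounds named here, the only step available, from compound 1 to compound 2, was within the scatter, and the three values together give no sign that small changes move the read-out.

Compound 4 is therefore expected to stay close to compound 1, with a step of about a number 3 percentage points lower from compound 1 to compound 4 (within the scatter), and its estimated value is 92%, in a range from 70% to 100%.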

Compound 4, a percentage reported as activity, at one concentration (the size of the read-out at that concentration, not a potency): 100%
Estimate against measurement, compound 4: 8 percentage points below; the range from low to high includes it.
By their numbers in this assay, from the lowest: compounds 1, 2, 3 and 4 (each within the scatter of the next).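

Among these compounds, the step from ethyl to hexyl is the only measured change that touches the length of this chain. In this assay, butyl in place of hydrogen on a saturated chain carbon, two bonds along the chain from an aromatic carbon, gives a number 5 percentage points higher from compound 1 to compound 4 (within the scatter). Among the compounds shown here, this read-out therefore does not separate the ethyl and hexyl compounds, so a chain extended by these 4 carbon atoms at this position leaves the result within the scatter, which the earlier compounds, with no change at this position, could not show. Nothing in the available evidence bears on this chain change, and the result comes with no explanation.

The compounds shown leave open whether a longer chain such as octyl, or a chain ending in an amine or a carboxylic acid, would give a number outside the scatter of compound 1 in this assay. They also leave open whether the hexyl chain would give a similar number with the stereocentre drawn as in compound 2.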